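The compounds below may be only part of what the source reports. "The series", "measured", "known", "first", "only" and "open" are said of these compounds alone.

Compound 1 `CC/C=C\C[C@H]1C(=O)C=C[C@H]1CC(=O)OCC` is an ester of a cyclopentenone acid. Among the compounds with values here, in an ADME assay on RAW264.7 cells (Mus musculus) for cytotoxicity, read by MTT assay, with a stated time of 24 h (a lower number here means that less compound is tolerated, a higher number that more compound is tolerated), compound 1 gives 146 uM, the second highest of the three numbers so far. Its nearest neighbour is compound 3 `CC/C=C\C[C@H]1C(=O)C=C[C@H]1CC(=O)OCCO`, which in this assay gives 161 uM; the step of a 1.1-fold higher number from compound 1 to compound 3 (0.04 log units; within the scatter) lies within the scatter. Its furthest is compound 2 `CC/C=C\C[C@H]1C(=O)C=C[C@H]1CC(=O)OCCCC`, which in this assay gives 31 uM; the step of a 4.7-fold lower number from compound 1 to compound 2 (0.67 log units; beyond the scatter) is modest but beyond the scatter. The step of a 5.2-fold higher number from compound 2 to compound 3 (0.72 log units; beyond the scatter) is of similar size in the other direction.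

Compound 4 `CC/C=C\C[C@H]1C(=O)C=C[C@H]1CC(=O)OC(C)c1ccccc1` has not yet been measured. It differs from compound 1 by phenyl in place of hydrogen on a saturated chain carbon bound to an oxygen next to a carbonyl group and a saturated chain carbon. Within the data shown here, two measured steps bear on this change, as both also alter the alcohol part of the ester. Adding ethyl on the chain gave a 4.7-fold lower number from compound 1 to compound 2 (0.67 log units; beyond the scatter), while adding hydroxy gave a 1.1-fold higher number from compound 1 to compound 3 (0.04 log units; within the scatter). Phenyl is a carbon-only group like ethyl and larger, so a step in the same direction as a 4.7-fold lower number from compound 1 to compound 2 (0.67 log units; beyond the scatter) is expected, of at least that size. For compound 4 the expected step is therefore a 5.2-fold lower number from compound 1 to compound 4 (0.72 log units; beyond the scatter). Compound 4 is thus estimated at 28 uM in this assay, with a range from 11 uM to 75 uM.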

Compound 4, half-maximal toxic concentration: 31 uM
Compound 4: the middle estimate sits 1.1-fold (0.04 log units) below what was measured; measured number inside the range.
By their numbers in this assay, from the lowest: compounds 2 and 4 (each within the scatter of the next); then compounds 1 and 3 (each within the scatter of the next).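

In this assay phenyl on a saturated chain carbon bound to an oxygen next to a carbonyl group and a saturated chain carbon gives a 4.7-fold lower number from compound 1 to compound 4 (0.67 log units; beyond the scatter). This shows that a change on this carbon, and not only one two bonds along the chain from that oxygen, can move the number beyond the scatter. Ethyl and phenyl, both carbon-only groups, each lower the number beyond the scatter from compound 1 although they sit on different carbons, whereas hydroxy in compound 3 goes against any general lowering and stays within the scatter of compound 1; no measurement shown here gives a cause for the step to compound 4.

The compounds shown leave open whether phenyl would give a similar step two bonds along the chain from the oxygen, or ethyl and hydroxy a similar step on the carbon that carries phenyl in compound 4, so the roles of group and place remain unseparated. They also leave open how this assay would respond to an amine, a carboxylic acid or a longer chain in the alcohol part of the ester.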